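Sulfonamide series: amine substituent swap from compound 2 to compound 3

The source may hold more compounds than are shown below. What is called first, only, known or untested is meant among the compounds shown, and "the series" means these compounds.

Two members of this sulfonamide series have been measured. Compound 1 `O=S(=O)(NCCCNCC1COc2ccccc2O1)c1cc(C(F)(F)F)cc(C(F)(F)F)c1` in a functional assay on HPAC cells (Homo sapiens) for inhibition, read by MTT assay, with a stated time of 72 h (on this read-out lower numbers stand for stronger inhibition of growth and higher numbers for weaker inhibition of growth), gives 2700 nM. Compound 2 `CN(CCCNS(=O)(=O)c1cc(C(F)(F)F)cc(C(F)(F)F)c1)Cc1ccccc1` in this assay gives 30000 nM, the highest of the two numbers shown; compound 1 sits below it by a gap that exceeds the scatter of the method, though the two structures differ in more than one place and no single step connects them.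

Compound 3 `COc1cccc(CNCCCNS(=O)(=O)c2cc(C(F)(F)F)cc(C(F)(F)F)c2)c1` is not yet measured. It differs from compound 2 by (3-methoxybenzyl)amino in place of benzyl(methyl)amino on a saturated chain carbon, three bonds along the chain from a sulfonamide nitrogen, so the methyl on the amine is gone while a methoxy appears on the benzyl ring.

With no measured step of this kind in the series, the expectation rests on the weak standing of compound 2 alone. For compound 3 the estimate is 10000 nM in this assay, with a range from 3000 nM to 30000 nM. The expected step from compound 2 to compound 3 is a 3.0-fold lower number from compound 2 to compound 3 (0.48 log units; beyond the scatter), a modest move toward stronger growth inhibition that may not clear the scatter.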

Compound 3, concentration for 50% growth inhibition: 2400 nM
The estimate for compound 3 lay 4.2-fold (0.62 log units) above the measured number; measured number below the stated range.
By their numbers in this assay, from the lowest: compounds 3 and 1 (each within the scatter of the next); then compound 2.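

In this assay the place on a saturated chain carbon, three bonds along the chain from a sulfonamide nitrogen, proves sensitive: (3-methoxybenzyl)amino in place of benzyl(methyl)amino gives a 13-fold lower number from compound 2 to compound 3 (1.10 log units; beyond the scatter) and so is a large step, which shows that a benzyl ring at this place is compatible with a number like that of compound 1. The 3-methoxyphenyl in place of 2,3-dihydro-1,4-benzodioxin-2-yl on a saturated chain carbon bound to an amine nitrogen gives a 1.1-fold lower number from compound 1 to compound 3 (0.05 log units; within the scatter) and does not separate these two groups in this read-out. Nothing measured here accounts for the large step, which combines the loss of the methyl on the amine, the gain of the amine hydrogen and the gain of the methoxy on the benzyl ring.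

The compounds shown leave open which of these parts carries the step: benzylamino and (3-methoxybenzyl)(methyl)amino would divide it. Also open, on these data alone, is whether the methoxy matters at this ring position, which 2-methoxybenzylamino or 4-methoxybenzylamino would address.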